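This account rests on a few compounds, and the source may have more. Where it says the series, first, only, none or still open, it means among the compounds named here.

Measured compounds so far:

Compound 1, `COc1cc(OC)c2cc(-c3ccccc3)c(O)nc2c1`: 10000 nM
Compound 2, `COc1ccc(-c2cc3cccc(OC)c3nc2O)cc1`: 10000 nM
Compound 3, `COc1ccc(-c2cc3c(OC)cc(OC)cc3n(C)c2=O)cc1`: 10000 nM

All three compounds were tested in a functional assay on A-427 cells (Homo sapiens) for cytotoxicity, read by colorimetric assay and MTT assay; a lower number here means a stronger inhibitor, a higher number a weaker inhibitor. In this assay compound 3 gives 10000 nM. Compound 1 gives 10000 nM in the same assay, and compound 2 gives 10000 nM. At the digits reported, compound 3 stands level with compound 1 and compound 2: the gaps between them lie within the usual scatter of repeated measurements, so none of the three can be called more or less potent than another. Every one of them is a weak inhibitor of these cells.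

Compound 4, `COc1ccc(-c2cc3c(OC)cc(OC)cc3n(CC(=O)OCc3ccccc3)c2=O)cc1`, is the next compound to be measured. It differs from compound 3 in one place: benzyloxycarbonyl in place of hydrogen on a saturated chain carbon bound to an aromatic nitrogen. Among the compounds with values here, no pair of measured compounds here differs in a single place, so no measured step is available to guide an expectation of how large such a change might be. Given that compound 3 gives 10000 nM, the step of no change at the digits printed from compound 3 to compound 4 (within the scatter) is expected to be none beyond the scatter. Compound 4 is therefore estimated at 10000 nM in this assay, with a likely range from 3000 nM to 30000 nM.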

Compound 4, half-maximal inhibitory concentration: 10000 nM
The estimate for compound 4 equals the measured number at the digits printed; measured number inside the range.
By their numbers in this assay, from the lowest: compounds 1, 2, 3 and 4 (each within the scatter of the next).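

In this assay, within the data shown here, the first single-place change that can be read gives no change at the digits printed from compound 3 to compound 4 (within the scatter) when benzyloxycarbonyl takes the place of hydrogen on a saturated chain carbon bound to an aromatic nitrogen, which can also be read as methyl to (benzyloxycarbonyl)methyl. This position therefore carries a much bigger group, one that brings a six-membered aromatic ring of carbon only and a double bond outside aromatic rings, without any shift beyond the scatter in this assay. Nothing available explains why the number stays put.

The compounds shown leave open whether a carboxylic acid or an amine in place of benzyloxycarbonyl on this chain carbon would move the number away from this level. They also leave open whether a longer chain between the aromatic nitrogen and benzyloxycarbonyl would do so.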